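Cytotoxicity of a nitrophenyl analogue: an estimate

The compounds below may be only part of what the source reports. "The series", "measured", "known", "first", "only" and "open" are said of these compounds alone.

Compound 1 `CCOC(=O)CCCCCOc1cccc(CN(C(=O)c2ccc(-c3cccnc3)cc2)C(C)C)c1`: in an ADME assay on HepG2 cells (Homo sapiens) for cytotoxicity, read by CellTiter-Glo and resazurin assay, with a stated time of 72 h (a lower number here means that less compound is needed, a higher number that more compound is needed for the effect), compound 1 gives > 26000 nM, which is a limit of the assay rather than a number.
Compound 2 `CCOC(=O)CCCCCOc1cccc(CN(C(=O)c2ccc(-c3cc(F)cc(OC)c3)cc2)C(C)C)c1`: compound 2 gives > 26000 nM, also a limit.
Compound 3 `CCOC(=O)CCCCCOc1cccc(CN(C(=O)c2ccc(-c3ccc(Cl)c(Cl)c3)cc2)C(C)C)c1`: compound 3 gives > 26000 nM, again a limit.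

Compound 3 therefore stands at the limit together with both other compounds, as the limit of > 26000 nM in this assay, at which 3 of the 3 values shown sit, records. The steps a step that the two limits leave unreadable from compound 1 to compound 2, a step that the two limits leave unreadable from compound 1 to compound 3 and a step that the two limits leave unreadable from compound 2 to compound 3 cannot be read for size or direction. Compound 4 `CCOC(=O)CCCCCOc1cccc(CN(C(=O)c2ccc(-c3cccc([N+](=O)[O-])c3)cc2)C(C)C)c1` differs from compound 3 by 3-nitrophenyl in place of 3,4-dichlorophenyl on an aromatic carbon. Among the measured compounds shown here, since no measured step can be sized, no change beyond the scatter is expected. Compound 4 is estimated at 26000 nM (range 9000 nM to 80000 nM), most likely reported as a limit once more. The step from compound 3 to compound 4 is accordingly expected to be a number no higher from compound 3 to compound 4 (the limit leaves the size open).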

Compound 4, half-maximal effective concentration: > 26000 nM
Compound 4: only a limit was reported; the forecaster's own chance of this, stated with the estimate: 85%; the middle value lies on the limit itself.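

Among the compounds shown here, compound 4 gives a limit rather than a number, as do compound 1, compound 2 and compound 3, so no step among them can be read in this assay, where all four share one reading: the limit of > 26000 nM in this assay, at which 4 of the 4 values shown sit.

The compounds shown leave open how much compound each of the four would need for the effect, and whether the different aromatic groups change it at all.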